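A tert-butoxycarbonyl in place of a butanoyl on the core

A few compounds are considered here, and "the series" means these few. Any claim that something is new, unique, unknown or untested is made for them only; others in the source may bear on it.

Compound 1 `Cc1[nH]nc(N)c1-c1cccc(Cl)c1` gives 93400 nM in an assay on Sf9 cells for inhibition of inhibitor of nuclear factor kappa-B kinase subunit epsilon (Homo sapiens), read by ADP-Glo, with a stated time of 60 min; on this read-out higher numbers stand for weaker inhibition and lower numbers for stronger inhibition. Compound 2 `CCCC(=O)n1nc(C)c(-c2ccc(Cl)c(Cl)c2)c1N` reaches only the limit of this assay, > 100000 nM, so no number is known for it; it sits at the limit of > 100000 nM in this assay, at which 1 of the 2 values shown sits. Compound 3 `Cc1nn(C(=O)OC(C)(C)C)c(N)c1-c1ccc(Cl)c(Cl)c1` differs from compound 2 by tert-butoxy in place of propyl on a carbonyl carbon. Among the measured compounds shown here, with no measured step to rest on, the change from compound 2 to compound 3 is expected to bring no shift beyond the usual scatter, and compound 3 is expected to remain at or past the limit, estimated at 150000 nM with a range from 50000 nM to 500000 nM, a step that the limit leaves unreadable from compound 2 to compound 3.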

Compound 3, half-maximal inhibitory concentration: > 100000 nM
Compound 3: a limit, no number; the forecaster's own chance of this, stated with the estimate: 80%; the middle value lies beyond the limit too.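

In this assay compound 3 gives > 100000 nM, a limit and not a number. Compound 2 also stands at a limit, so the step between compound 2 and compound 3 cannot be read. Going by these compounds, whether tert-butoxy in place of propyl on a carbonyl carbon changes inhibition at all remains open.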